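Diethylamino to cyclopentylamino on the 3,4-difluorophenyl series

The source may hold more compounds than are shown below. What is called first, only, known or untested is meant among the compounds shown, and "the series" means these compounds.

Values in a functional assay on A2780 cells (Homo sapiens) for antiproliferative activity, read by MTT assay, with a stated time of 72 h; on this read-out higher numbers stand for weaker inhibition and lower numbers for stronger inhibition:
- compound 1 `CC(C)CNC(=N)NC(=N)Nc1ccc(F)c(F)c1`: 6700 nM
- compound 2 `CCN(CC)C(=N)NC(=N)Nc1ccc(F)c(F)c1`: 20400 nM
- compound 3 `N=C(NC(=N)NC1CCCC1)Nc1ccc(F)c(F)c1`: not yet measured

Of the two measured compounds, compound 2 has the higher number in this assay, at 20400 nM, and so is the weaker inhibitor. The next change is cyclopentylamino in place of diethylamino on a carbon with a double bond to nitrogen. Going by the values given here, one measured step bears on it, a change at the same place: a 3.0-fold higher number from compound 1 to compound 2 (0.48 log units; beyond the scatter). That step is modest but beyond the scatter, and it went upward when diethylamino replaced isobutylamino. Compound 3 gives up diethylamino, and cyclopentylamino resembles the isobutylamino of compound 1 more closely. A step of similar size towards a lower number is therefore expected, although a single pair is thin evidence and no ring at this place has been measured. The expected change is a 2.6-fold lower number from compound 2 to compound 3 (0.41 log units; beyond the scatter). Compound 3 is estimated at 8000 nM, with an expected range of 3500 nM to 18000 nM.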

Compound 3, half-maximal inhibitory concentration: 9300 nM
For compound 3 the middle estimate is 1.2-fold (0.07 log units) below the measured one; measured number inside the range.
By their numbers in this assay, from the lowest: compounds 1 and 3 (each within the scatter of the next); then compound 2.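

In this assay the change from diethylamino to cyclopentylamino gives a 2.2-fold lower number from compound 2 to compound 3 (0.34 log units; beyond the scatter), which shows that a number well under that of the diethylamino compound can be reached at this place with a five-membered ring as well as with the branched isobutyl chain. Cyclopentyl in place of isobutyl on an amine nitrogen gives a 1.4-fold higher number from compound 1 to compound 3 (0.14 log units; within the scatter), so these two groups cannot be told apart here, and among the three compounds only the diethylamino one stands apart from the others. The step from diethylamino brings in the ring and takes the hydrogen-bond donors of the group from 0 to 1 at the same time, and nothing available explains the shift in this read-out.

Still open, on these data alone, is whether a pyrrolidine ring on the same carbon, which would keep a ring while leaving no hydrogen on that nitrogen, would follow cyclopentylamino or diethylamino. Also open, as far as these compounds go, is how far the range extends with a smaller cyclopropyl ring, a larger cyclohexyl ring or a longer unbranched chain such as hexyl on that nitrogen.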